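From compound 2 to compound 4: decyl for substituted benzyl

This account rests on a few compounds, and the source may have more. Where it says the series, first, only, none or still open, it means among the compounds named here.

In a physicochemical assay for lipophilicity (on this read-out lower numbers stand for lower lipophilicity and higher numbers for higher lipophilicity), compound 2 `COc1cc(Cn2c(=O)cc(N3CCC[C@@H](N)C3)n(Cc3cc(F)ccc3C#N)c2=O)cc(Br)c1OC` stands highest of three at 3.49 and lies clearly above compound 1 `CC#CCn1c(N2CCC[C@@H](N)C2)cc(=O)n(Cc2cc(Br)c(OC)c(OC)c2)c1=O` at 2.38 and compound 3 `CC#CCn1c(N2CCC[C@@H](N)C2)cc(=O)n(CCCCCC)c1=O` at 2.15 in this small set. The change to compound 4 `CCCCCCCCCCn1c(=O)cc(N2CCC[C@@H](N)C2)n(Cc2cc(F)ccc2C#N)c1=O` is nonyl in place of 3-bromo-4,5-dimethoxyphenyl on a saturated chain carbon bound to an aromatic nitrogen with nonyl in place of 3-bromo-4,5-dimethoxyphenyl on a saturated chain carbon bound to an aromatic nitrogen. Among the measured compounds shown here, the one measured step of a number 1.11 log units higher from compound 1 to compound 2 (beyond the scatter) was large but replaces a group that compound 4 retains, and no measured step covers this change directly. With 3-bromo-4,5-dimethoxybenzyl compound 1 reads 2.38 and with hexyl at that place compound 3 reads 2.15 within the usual scatter of each other. Decyl is a longer chain than hexyl, yet no measurement so far tests chain length. The estimated step of a number 1.41 log units higher from compound 2 to compound 4 (beyond the scatter) is upward and large. For compound 4 the expected value is 4.9 with an estimated range from 4.1 to 5.7 in this assay terms.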

Compound 4, partition coefficient: 4.93
The estimate for compound 4 lay 0.03 log units below the measured number, within the range that was stated.
By their numbers in this assay, from the lowest: compounds 3 and 1 (each within the scatter of the next); then compound 2; then compound 4.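

In this assay, exchanging 3-bromo-4,5-dimethoxybenzyl for decyl on the shared core gives a number 1.44 log units higher from compound 2 to compound 4 (beyond the scatter). Compound 1 and compound 3 stand within the scatter of each other with 3-bromo-4,5-dimethoxybenzyl and hexyl at this place, so the pair did not show that the group here can move the read-out, whereas the decyl exchange shows that it can. No supporting evidence explains the size of this step.

The compounds shown leave open how the read-out follows chain length at this place, since hexyl and decyl sit on different groups elsewhere in compound 3 and compound 4. They also leave open whether an octyl chain would fall between those two chains, and how a decyl chain ending in an amine or a carboxylic acid would read.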